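Swapping a thioether link for a benzylamine on a diamino core

This account rests on a few compounds, and the source may have more. Where it says the series, first, only, none or still open, it means among the compounds named here.

Measured so far:
Compound 1, `Nc1cc(N)c2nc(-c3ccccc3)c(Sc3ccc(F)cc3)nc2c1`: 66100 nM
Compound 2, `COc1cc(CNc2nc3cc(N)cc(N)c3nc2-c2ccccc2)cc(OC)c1OC`: < 50200 nM
Compound 3, `CCOC(=O)[C@H](CCC(=O)O)NC(=O)c1ccc(Oc2nc3cc(N)cc(N)c3nc2-c2ccccc2)cc1`: < 100000 nM

Of the compounds shown here, three sharing the same diamino core have been tested in a functional assay on NCI-H460 cells (Homo sapiens) for inhibition, read by sulforhodamine B assay, with a stated time of 48 h; on this read-out lower numbers stand for stronger inhibition of growth and higher numbers for weaker inhibition of growth. Compound 1 gives 66100 nM, and it is the only one of the three with an actual number. Compound 2 is reported only as a limit, (the limit of < 50200 nM in this assay, at which 1 of the 3 values shown sits), so no number is known for it. Compound 3 likewise is reported only as a limit, (the limit of < 100000 nM in this assay, at which 1 of the 3 values shown sits). Two of the three results are limits. For the measured compounds named here, no step between measured compounds can be drawn, and compound 1 is simply the one fixed point.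

Compound 4, `Nc1cc(N)c2nc(-c3ccccc3)c(NCc3ccc(F)cc3)nc2c1`, is the next candidate. It differs from compound 1 in one place: (4-fluorobenzyl)amino in place of (4-fluorophenyl)sulfanyl on an aromatic carbon. The rest of the molecule stays as it is.

Going by the values given here, with no measured step to lean on, a modest shift is expected, in the direction of stronger growth inhibition, and the step from compound 1 to compound 4 is estimated as a 1.7-fold lower number from compound 1 to compound 4 (0.22 log units; within the scatter). Compound 4 is expected to come out near 40000 nM, somewhere between 10000 nM and 100000 nM.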

Compound 4, concentration for total growth inhibition: 25700 nM
Compound 4: middle estimate off by 1.6-fold (0.19 log units), on the high side, within the range that was stated.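

In this assay, for the compounds shown here, replacing (4-fluorophenyl)sulfanyl with (4-fluorobenzyl)amino on the aromatic carbon next to the ring nitrogen gives the first readable change at this position: a 2.6-fold lower number from compound 1 to compound 4 (0.41 log units; beyond the scatter). The core and its phenyl group stay the same, so this shift belongs to the swapped group alone, and growth inhibition is stronger with the benzylamine in place of the thioether. That swap alters two things together, turning the sulfur link into an amino nitrogen that brings a hydrogen-bond donor and the fluorophenyl group into a fluorobenzyl group, and nothing measured here shows why the number moves.

Steps involving compound 2 and compound 3 cannot be read, as both are reported only as limits. Still open, going by these compounds, is which part of the swap carries the shift, and how a plain benzylamino group without the fluorine, or a longer phenethylamino chain, would behave at this same position on the core.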